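Adding a Second Methoxy Group: A Small Step Expected

The compounds below may be only part of what the source reports. "The series", "measured", "known", "first", "only" and "open" are said of these compounds alone.

Of the compounds shown here, three of one shared core have been measured in a functional assay on MCF7 cells (Homo sapiens) for inhibition, read by sulforhodamine B assay, with a stated time of 48 h; a lower number here means a stronger inhibitor of growth, a higher number a weaker inhibitor of growth. Compound 1 `COc1ccc(-c2cc(/C=C/C(=O)c3ccc(N)cc3)[nH]n2)cc1` gives 3840 nM in this assay. Compound 2 `COc1ccc(C(=O)/C=C/c2cc(-c3cc(OC)c(OC)c(OC)c3)n[nH]2)cc1` gives 2960 nM, and compound 3 `COc1cc(-c2cc(/C=C/C(=O)c3ccc(F)c(F)c3)[nH]n2)cc(OC)c1OC` gives 12300 nM. Among these three numbers compound 1 stands second highest: its gap to compound 2 lies within the scatter, while compound 3 sits well beyond it. Among the measured compounds shown here, the only step between compounds differing in one place is a 4.2-fold higher number from compound 2 to compound 3 (0.62 log units; beyond the scatter), which concerns the aryl ring on the carbonyl carbon and not the ring changed here.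

Compound 4 `COc1ccc(-c2cc(/C=C/C(=O)c3ccc(N)cc3)[nH]n2)cc1OC` differs from compound 1 by methoxy in place of hydrogen on an aromatic carbon. For the measured compounds named here, no measured step isolates this change. The nearest guide is the pair of compound 1 and compound 2: compound 2 carries three methoxy groups on the same ring and differs on the other aryl ring as well, yet its value sits within the scatter of compound 1. The expectation is therefore a step of a 1.2-fold lower number from compound 1 to compound 4 (0.07 log units; within the scatter), not beyond the scatter in either direction. Compound 4 is estimated at 3300 nM in this assay, within a range from 1500 nM to 7500 nM.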

Compound 4, concentration for total growth inhibition: 8480 nM
For compound 4 the middle estimate is 2.6-fold (0.41 log units) below the measured one; the measured number lies above the stated range.
By their numbers in this assay, from the lowest: compounds 2 and 1 (each within the scatter of the next); then compounds 4 and 3 (each within the scatter of the next).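

In this assay, placing a methoxy group on an aromatic carbon ortho to a methoxy group and meta to a large group gives a 2.2-fold higher number from compound 1 to compound 4 (0.34 log units; beyond the scatter). Among the compounds shown here, this step is modest but lies beyond the scatter, so this position on the ring is not silent: here, the added methoxy group goes with weaker growth inhibition, a direction the earlier compounds could not show because none of their steps isolated a change on this ring. The step gives only the size and direction of the change, and no measurement shown here offers an explanation for it.

Going by these compounds, what remains open is whether this result is specific to methoxy or would also appear with a different group at the same position, such as a fluorine atom, a hydroxyl group or a longer chain like ethoxy. On these data alone, it is also open whether the same step would appear with a different group in place of the amine on the aryl ring at the carbonyl carbon, since this single pair carries only that amine.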